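The source may hold more compounds than are shown below. What is called first, only, known or untested is meant among the compounds shown, and "the series" means these compounds.

Working notes on the series. Three analogues sharing one core have been measured in a functional assay on A549 cells (Homo sapiens) for inhibition, with a stated time of 72 h; on this read-out lower numbers stand for stronger inhibition and higher numbers for weaker inhibition: compound 1 `O=C(Nc1ccc(Cl)cc1)Nc1nc(Sc2c[nH]c3ccccc23)cc(N2CCCC2)n1` gives 6410 nM, compound 2 `O=C(Nc1ccccc1)Nc1nc(Sc2c[nH]c3ccccc23)cc(N2CCCC2)n1` gives 21200 nM, and compound 3 `COc1ccc(NC(=O)Nc2nc(Sc3c[nH]c4ccccc34)cc(N3CCCC3)n2)cc1` gives 11800 nM. Within the data shown here, compound 2 carries the highest of the three numbers; its nearest neighbour is compound 3, at a step of a 1.8-fold lower number from compound 2 to compound 3 (0.25 log units; within the scatter), and the only step beyond the scatter in the set is a 3.3-fold higher number from compound 1 to compound 2 (0.52 log units; beyond the scatter), a change of hydrogen in place of chloro on an aromatic carbon of the urea-bound phenyl. The step of a 1.8-fold higher number from compound 1 to compound 3 (0.27 log units; within the scatter) stays within the scatter.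

Compound 4 `O=C(Nc1ccccc1)Nc1nc(Nc2ccc(Cl)cc2)cc(Sc2c[nH]c3ccccc23)n1` is not yet measured. Against compound 2 it shows ((4-chlorophenyl)amino in place of pyrrolidin-1-yl on an aromatic carbon). Among the measured compounds shown here, all three measured steps concern the urea-bound phenyl and leave the pyrrolidin-1-yl untouched, so none of them bears directly on this change; the data give no measured precedent for (4-chlorophenyl)amino at this position. For the measured compounds named here, with no comparable step available, the expectation for compound 4 is kept close to compound 2, as a step of a 1.8-fold lower number from compound 2 to compound 4 (0.25 log units; within the scatter) within this assay. In this assay compound 4 is therefore estimated at 12000 nM, with a range from 3000 nM to 50000 nM.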

Compound 4, half-maximal inhibitory concentration: 48400 nM
Compound 4: middle estimate off by 4.0-fold (0.61 log units), on the low side, within the range that was stated.
By their numbers in this assay, from the lowest: compounds 1, 3 and 2 (each within the scatter of the next, the first and the last beyond it); then compound 4.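

The pyrrolidin-1-yl position is now shown to affect the read-out in this assay: replacing that group with (4-chlorophenyl)amino gives a 2.3-fold higher number from compound 2 to compound 4 (0.36 log units; beyond the scatter), a modest change but the first measured one at this site, as all earlier steps concerned the urea-bound phenyl. The change replaces a five-membered non-aromatic ring with an aromatic ring of carbon only, adds a chlorine and brings in a hydrogen-bond donor, so this single step does not separate the contributions of these features. No supporting data are available to explain the direction or size of the step.

A single replacement cannot show how the read-out responds across this position; phenylamino without the chlorine would isolate the chlorine within the entering group, while N-methyl-N-phenylamino would remove the hydrogen-bond donor and piperidin-1-yl or morpholin-4-yl would test other non-aromatic rings. Going by these compounds, it also remains open whether a chloro group on the urea-bound phenyl, which accompanies the lower number of compound 1 relative to compound 2, would have the same effect alongside (4-chlorophenyl)amino at this position.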